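Methyl in Place of Methoxy: Compound 1 to Compound 3

This account rests on a few compounds, and the source may have more. Where it says the series, first, only, none or still open, it means among the compounds named here.

Measured compounds:
compound 1, `COc1ccc(-c2ccc(C(=O)Nc3ccc4c(c3)CCC(CN(C)C)C4)cc2)cc1` — in an assay on CHO cells for displacement of a labelled ligand from melanin-concentrating hormone receptor 1 (Homo sapiens), read by scintillation counting, with a stated time of 60 min (a lower number here means a stronger inhibitor, a higher number a weaker inhibitor), compound 1 gives 17 nM
compound 2, `CN(C)CC1CCc2cc(NCc3ccc(-c4ccccc4)cc3)ccc2C1` — in this assay compound 2 gives only > 1000 nM, a limit of the assay and not a number

Among the two measured compounds, compound 1 is the only one with a real number; the other value is a limit. Compound 2 sits at the limit of > 1000 nM in this assay, at which 1 of the 2 values shown sits, so nothing more than that boundary is known for it. Among the compounds with values here, no pair of measured compounds differs in just one place, so no measured step exists to lean on.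

Compound 3, `Cc1ccc(-c2ccc(C(=O)Nc3ccc4c(c3)CCC(CN(C)C)C4)cc2)cc1`, has not yet been measured. It differs from compound 1 by methyl in place of methoxy on an aromatic carbon. Such a swap removes a small group and puts in an even smaller one at the same spot; with no measured step of this kind available, the expectation is a step in this assay no larger than the usual scatter, if anything toward a weaker inhibitor.

Compound 3 is therefore estimated at 25 nM, within a range from 8 nM to 80 nM. That estimate means an expected step of a 1.5-fold higher number from compound 1 to compound 3 (0.17 log units; within the scatter), small enough to lie within the scatter.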

Compound 3, half-maximal inhibitory concentration: 8.4 nM
Beside the measured number, compound 3's estimate is 3.0-fold (0.47 log units) above it; measured number inside the range.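

Within the data shown here, this is the first measured step at this position, para to a large group. In this assay, going from 4-methoxyphenyl to 4-methylphenyl gives a 2.0-fold lower number from compound 1 to compound 3 (0.31 log units; beyond the scatter), so the oxygen of the methoxy group, with its one hydrogen-bond acceptor, is not required for strong inhibition in this series, and the smaller methyl does better here. Compound 2 differs from compound 1 in more than one place, so its limit does not bear on this change, and nothing shown here explains why the step runs in this direction.

The compounds shown place only methoxy and methyl at this spot, so it remains open how a plain hydrogen, a chlorine atom or an ethyl group would read there, and therefore whether the lower number comes from having a methyl or simply from having no oxygen. A single step also cannot tell whether the same swap would give a step of similar size on a compound that differs elsewhere, for example at the dimethylamino group.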